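Ring methyl removal on the piperazine of compound 3

A few compounds are considered here, and "the series" means these few. Any claim that something is new, unique, unknown or untested is made for them only; others in the source may bear on it.

Measured compounds in a functional assay for agonist activity at growth hormone secretagogue receptor type 1 (Homo sapiens), read by FLIPR; on this read-out lower numbers stand for an effect already at smaller amounts and higher numbers for an effect only at larger amounts of compound:
- compound 1, `COc1cc2c(cc1N1C[C@@H](C)N[C@@H](C)C1)N(S(=O)(=O)CCc1ccccc1Cl)CC2`: compound 1 gives 5.01 nM
- compound 2, `COc1cc2c(cc1N1C[C@@H](C)N[C@@H](C)C1)N(S(=O)(=O)c1ccc(-c3ccon3)s1)CC2`: compound 2 gives 2.51 nM
- compound 3, `COc1cc2c(cc1N1CCN[C@@H](C)C1)N(S(=O)(=O)c1ccc(-c3ccccn3)s1)CC2`: compound 3 gives 3.16 nM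

All three numbers sit close together. Compound 3 stands second highest of the three, nearest to compound 2 and furthest from compound 1, and both gaps are within the scatter, so no order among them can be read. Compound 2 and compound 3 differ in two places at once, so their two values show only that both lie in the same narrow band.

The unmeasured compound 4, `COc1cc2c(cc1N1CCNCC1)N(S(=O)(=O)c1ccc(-c3ccccn3)s1)CC2`, arises from compound 3 by hydrogen in place of methyl on a saturated ring carbon of the six-membered non-aromatic ring with two nitrogens; cut one bond further out, 3-methylpiperazin-1-yl becomes piperazin-1-yl.

Among the measured compounds shown here, the only single-site step measured, a 2.0-fold lower number from compound 1 to compound 2 (0.30 log units; within the scatter), concerns the group on the sulfonyl sulfur and does not touch the ring in question. For the measured compounds named here, no measured step probes the ring methyl, so nothing here argues for a shift beyond the scatter in this assay in either direction.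

Compound 4 is therefore expected to come out close to compound 3, with a 1.3-fold higher number from compound 3 to compound 4 (0.10 log units; within the scatter) as the estimated step. The estimate for compound 4 is 4 nM, with a range from 1.3 nM to 13 nM.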

Compound 4, half-maximal effective concentration: 63.1 nM
The estimate for compound 4 lay 16-fold (1.20 log units) below the measured number, outside the stated range (above it).
By their numbers in this assay, from the lowest: compounds 2, 3 and 1 (each within the scatter of the next); then compound 4.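

In this assay, among the compounds shown here, the single methyl of 3-methylpiperazin-1-yl proves to matter: changing to piperazin-1-yl gives a 20-fold higher number from compound 3 to compound 4 (1.30 log units; beyond the scatter), the first step to lie beyond the scatter. The earlier compounds offered only one readable step, on the group at the sulfonyl sulfur, and it gave no view of this saturated ring carbon next to the ring nitrogen; the series is therefore sensitive here to the loss of one carbon, even though the compounds shown so far all sit in a narrow band. Nothing available accounts for the size of this step.

As far as these compounds go, it remains open whether the methyl itself is required or whether another group on the same ring carbon, such as an ethyl, a hydroxymethyl or a fluorine, would hold the number as low, and whether the opposite configuration of the methyl would do the same. From the compounds shown here alone, it is also open whether the loss of the methyl costs as much with a different group on the sulfonyl sulfur, such as the 2-(2-chlorophenyl)ethyl of compound 1.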